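Swapping the benzyl substituent on the shared core

The compounds below may be only part of what the source reports. "The series", "measured", "known", "first", "only" and "open" are said of these compounds alone.

Measured so far:
- compound 1, `CC(C)NC(=O)N1CCN(C(=S)SCc2cn(Cc3ccccc3F)nn2)CC1`, with 1620 nM in a functional assay on MGC-803 cells (Homo sapiens) for cytotoxicity, read by MTT assay, with a stated time of 72 h; a higher number here means a weaker inhibitor, a lower number a stronger inhibitor
- compound 2, `O=C(NCc1ccccc1)N1CCN(C(=S)SCc2cn(Cc3ccccc3F)nn2)CC1`, with 13300 nM in this assay

Compound 1 gives the lowest of the two numbers in this assay. Among the compounds with values here, its only neighbour is compound 2, and the single step that has been measured, an 8.2-fold higher number from compound 1 to compound 2 (0.91 log units; beyond the scatter), changes the group on the amide-type nitrogen at the urea end of the shared core, not the benzyl group on the other end.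

Compound 3, `COc1ccc(Cn2cc(CSC(=S)N3CCN(C(=O)NC(C)C)CC3)nn2)cc1`, has not yet been measured. It differs from compound 1 as follows: 4-methoxyphenyl in place of 2-fluorophenyl on a saturated chain carbon bound to an aromatic nitrogen. This change sits at the opposite end of the core from the change between compound 1 and compound 2, so the measured step offers no direct guide to its size or direction. With nothing in the data to tell how the aromatic ring on that chain carbon matters, the expectation for compound 3 in this assay is a number close to that of compound 1, a step of a 1.2-fold higher number from compound 1 to compound 3 (0.09 log units; within the scatter) that is expected to stay within the scatter. The estimate for compound 3 is therefore 2000 nM, with a range from 700 nM to 6000 nM.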

Compound 3, half-maximal inhibitory concentration: 99200 nM
Compound 3: the middle estimate sits 50-fold (1.70 log units) below what was measured; measured number above the stated range.
By their numbers in this assay, from the lowest: compound 1; then compound 2; then compound 3.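

In this assay, the choice of aromatic group on a saturated chain carbon bound to an aromatic nitrogen turns out to matter greatly: 4-methoxyphenyl in place of 2-fluorophenyl gives a 61-fold higher number from compound 1 to compound 3 (1.79 log units; beyond the scatter) and so a much weaker inhibitor. Within the data shown here, this is the first measured change at this position, and it is a larger step than the only earlier one, an 8.2-fold higher number from compound 1 to compound 2 (0.91 log units; beyond the scatter), which changed the group on the amide-type nitrogen instead. No measurement available here accounts for the size of this step.

The change from 2-fluorobenzyl to 4-methoxybenzyl swaps the substituent and also its printed ring number, so the compounds shown leave open whether the loss follows the fluorine leaving, the methoxy group entering, or the new ring number. Plain benzyl, 4-fluorobenzyl and 2-methoxybenzyl on the same core would separate these possibilities, and whether the same change behaves alike with benzyl in place of isopropyl on the amide-type nitrogen also remains open.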